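Lengthening a Side Chain on a Weak Inhibitor

The source may hold more compounds than are shown below. What is called first, only, known or untested is meant among the compounds shown, and "the series" means these compounds.

Compound 1 `C(=N/c1ccccc1)\c1cc(-c2ccccc2)no1` and compound 2 `CCc1cc2ccccc2nc1-c1cc(-c2ccccc2)no1` share the same core. In a functional assay on COLO 205 cells (Homo sapiens) for inhibition, read by MTT assay, with a stated time of 24 h (a lower number here means a stronger inhibitor, a higher number a weaker inhibitor), compound 1 gives 89100 nM. For compound 2 the same assay, this assay, reports only a limit, > 100000 nM, so compound 2 has no exact figure and sits at the edge of what the method can read (the limit of > 100000 nM in this assay, at which 1 of the 2 values shown sits). Compound 3 `CCCCCc1cc2ccccc2nc1-c1cc(-c2ccccc2)no1` differs from compound 2 by a single change: propyl in place of hydrogen on a saturated chain carbon, two bonds along the chain from an aromatic carbon. Within the data shown here, no step between two measured compounds is available to size such a change, so the expectation rests on where compound 2 stands alone. The expected step of a number no higher from compound 2 to compound 3 (the limit leaves the size open) is none beyond the usual scatter. For compound 3 the estimate is 100000 nM, within a range from 30000 nM to 300000 nM, and another limit-only reading is about as likely as a number.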

Compound 3, half-maximal inhibitory concentration: > 100000 nM
Compound 3 ended at the assay's limit (the forecaster's own chance of this, stated with the estimate: 60%); the middle value sits exactly at the limit.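

Compound 2 and compound 3 both give only a limit in this assay, not a number, so no step between them can be read: the limit of > 100000 nM in this assay, at which 2 of the 3 values shown sit.

Whether propyl in place of hydrogen changes inhibition at all, and in which direction or by how much, stays open with the compounds shown.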